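Chloro for Fluoro in Three Measured Compounds and One Unmeasured

A few compounds are considered here, and "the series" means these few. Any claim that something is new, unique, unknown or untested is made for them only; others in the source may bear on it.

Measured in a functional assay on L1210 cells (Mus musculus) for inhibition; on this read-out higher numbers stand for weaker inhibition and lower numbers for stronger inhibition:
compound 1, `O=C1CCCCC/C1=C\c1cccc(F)c1`, gives 382000 nM
compound 2, `O=C1CCCCC/C1=C\c1ccc(F)cc1`, gives 291000 nM
compound 3, `O=C1CCCCC/C1=C\c1cccc(Cl)c1`, gives 144000 nM

Compound 2 and compound 1 have the same atoms joined differently; the difference between the two cores is not broken down here, and their two values lie within the scatter of each other. From compound 1 to compound 3 the change is chloro in place of fluoro on an aromatic carbon, and it gave a 2.7-fold lower number from compound 1 to compound 3 (0.42 log units; beyond the scatter). Compound 4, `O=C1CCCCC/C1=C\c1ccc(Cl)cc1`, is not yet measured. It differs from compound 2 by chloro in place of fluoro on an aromatic carbon. This is the same kind of change, but the place differs: meta to a group of 9 heavy atoms in the first pair, para to a group of 9 heavy atoms in the second. Because compound 3 reached 144000 nM from compound 1, a step of a 2.6-fold lower number from compound 2 to compound 4 (0.42 log units; beyond the scatter) in this assay is expected for compound 4. Compound 4 is estimated at 110000 nM, likely between 50000 nM and 250000 nM.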

Compound 4, half-maximal inhibitory concentration: 83000 nM
Compound 4: the middle estimate sits 1.3-fold (0.12 log units) above what was measured; the range from low to high includes it.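

In this assay, chloro in place of fluoro on an aromatic carbon gave a 3.5-fold lower number from compound 2 to compound 4 (0.54 log units; beyond the scatter) and so matched the earlier step in direction and, within the scatter, in size: the same change on two cores in this assay, a 2.7-fold lower number (0.42 log units; beyond the scatter) from compound 1 to compound 3 and a 3.5-fold lower number (0.54 log units; beyond the scatter) from compound 2 to compound 4, 1.3-fold (0.12 log units) apart, within the scatter of two such steps. The change therefore carried from one core to the other in these two pairs, with the new step sitting para to a group of 9 heavy atoms. Two pairs show no more than that: they do not explain why the number falls, and they do not establish that the step would hold on any other core in the series.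

The compounds shown leave open how bromo, methyl or methoxy would read on the same aromatic carbons. They also leave open what an amine or a carboxylic acid would do there.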